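Replacing the trimethoxyphenyl arm with a furan ring

This account rests on a few compounds, and the source may have more. Where it says the series, first, only, none or still open, it means among the compounds named here.

Three compounds have been measured in a functional assay on COLO 205 cells (Homo sapiens) for inhibition, read by sulforhodamine B assay, with a stated time of 48 h, tested at 50 uM; on this read-out lower numbers stand for less inhibition of growth and higher numbers for more inhibition of growth at the one concentration tested:
compound 1 `COc1cc(/C=C/C(=O)/C=C/c2cc(OC)c(OC)c(OC)c2)ccc1OCc1cn(CCOc2cc(=O)oc3ccccc23)nn1` gives 86%
compound 2 `COc1cc(/C=C/C(=O)/C=C/c2cc(OC)c(OC)c(OC)c2)ccc1OCc1cn(CCCOc2cc(=O)oc3ccccc23)nn1` gives 74%
compound 3 `COc1cc(/C=C/C(=O)/C=C/c2cccc3ccccc23)ccc1OCc1cn(CCCCOc2cc(=O)oc3ccccc23)nn1` gives 50%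

Compound 1 stands highest of the three numbers; compound 2 lies lower and compound 3 lower still, both gaps beyond the scatter. Compound 4 `COc1cc(/C=C/C(=O)/C=C/c2ccco2)ccc1OCc1cn(CCOc2cc(=O)oc3ccccc23)nn1` has not yet been measured. It differs from compound 1 in one place: furan-2-yl in place of 3,4,5-trimethoxyphenyl on a double-bonded chain carbon bound to a double-bonded chain carbon. For the measured compounds named here, no step between two measured compounds isolates this change. Going by the values given here, compound 3, the one measured compound without the trimethoxyphenyl group, carries the lowest number, so a downward step in this assay beyond the scatter is expected, a number 31 percentage points lower from compound 1 to compound 4 (beyond the scatter). Compound 4 is therefore estimated at 55%, between 30% and 80%.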

Compound 4, percent growth inhibition at one concentration: 68%
Beside the measured number, compound 4's estimate is 13 percentage points below it, and the stated range covers the measured number.
By their numbers in this assay, from the lowest: compound 3; then compounds 4 and 2 (each within the scatter of the next); then compound 1.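

In this assay, for the compounds shown here, the change of 3,4,5-trimethoxyphenyl to furan-2-yl gives a number 18 percentage points lower from compound 1 to compound 4 (beyond the scatter) and is the first change at this position that can be read alone. The step is modest, and compound 4 keeps a clear part of the growth inhibition without the 3,4,5-trimethoxyphenyl group. Nothing available explains the step.

Still open, as far as these compounds go, is whether a pyridine ring or a phenyl ring carrying an amine at this position would stay closer to compound 1. From the compounds shown here alone, it is also open whether furan-2-yl gives a similar step with a longer chain to the triazole.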